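The source may hold more compounds than are shown below. What is called first, only, known or untested is meant among the compounds shown, and "the series" means these compounds.

In an ADME assay (liver) for metabolic stability, with Liver microsome (Homo sapiens) as the target, read by LC-MS, using microsomes and NADPH, with a stated time of 5 min, at 37 degrees C (a lower number here means slower removal, a higher number faster removal of the compound), compound 1 `CCn1c([C@@H](C)NS(=O)(=O)c2ccc(C#N)cc2)nc2ccc(C(F)(F)F)cc21` gives 34 mL.min-1.g-1. Compound 2 `CCn1c([C@@H](C)NS(=O)(=O)c2ccccn2)nc2ccc(C(F)(F)F)cc21` gives < 3 mL.min-1.g-1, which is a limit of the assay and not a number. This places compound 2 at the limit of < 3 mL.min-1.g-1 in this assay, at which 1 of the 2 values shown sits.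

Compound 3 `CCCn1cc(S(=O)(=O)N[C@H](C)c2nc3ccc(C(F)(F)F)cc3n2CC)c(C)n1` differs from compound 2 by a group of 9 heavy atoms (7 carbon, 2 nitrogen; one five-membered aromatic ring with 2 hetero atoms) in place of a group of 6 heavy atoms (5 carbon, 1 nitrogen; one six-membered aromatic ring with 1 hetero atom), on a sulfonyl sulfur. For the measured compounds named here, only one measured step bears on this place, an at least 11-fold lower number from compound 1 to compound 2 (1.05 log units; beyond the scatter), and it is large. Going by the values given here, it shows that the group on the sulfonyl sulfur can move the number in this assay strongly, but no measured compound carries the entering group. Compound 2 stands at a limit, so a measurable change would appear as a higher number, and a moderate rise is expected, smaller than the step to compound 2. For compound 3 the expected value is 10 mL.min-1.g-1, with an estimated range from 3 mL.min-1.g-1 to 30 mL.min-1.g-1. The expected change is an at least 3.3-fold higher number from compound 2 to compound 3 (0.52 log units; beyond the scatter).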

Compound 3, intrinsic clearance in microsomes: > 100 mL.min-1.g-1
Compound 3 gave a limit, no number; the forecaster's own chance of this, stated with the estimate: 20%; at least 10-fold (1.00 log units) between middle value and limit.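

For the compounds shown here, the group on the sulfonyl sulfur can move the number in this assay in both directions: the earlier compounds showed only a fall, whereas here the step is an at least 33-fold higher number from compound 2 to compound 3 (1.52 log units; beyond the scatter). The new group also exceeds the 4-cyanophenyl group, with an at least 2.9-fold higher number from compound 1 to compound 3 (0.46 log units; beyond the scatter), so the pyridin-2-yl and 4-cyanophenyl groups do not mark the upper end for this place. Compound 3 stands at a limit of the assay and not at a number, so the full size of both rises stays unknown: the limit of > 100 mL.min-1.g-1 in this assay, at which 1 of the 3 values shown sits.

The compounds shown do not tell whether the ring or the attached chains of the entering group carry the rise. Going by these compounds, it also remains open whether a methyl group in place of the propyl chain, or a plain phenyl or pyridin-3-yl group on the sulfonyl sulfur, would give a measurable number.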